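A few compounds are considered here, and "the series" means these few. Any claim that something is new, unique, unknown or untested is made for them only; others in the source may bear on it.

Of the compounds shown here, three that share one core have been measured in an ADME assay for permeability, using PAMPA, with a stated time of 30 min, at pH 7.4; on this read-out higher numbers stand for higher permeability and lower numbers for lower permeability. Compound 1 `Cc1cc(C)cc(Cc2ccc3c(NCCCNCc4ccco4)ccnc3c2)c1` gives 23 10^-6 cm/s in this assay, and compound 2 `c1coc(CNCCCNc2ccnc3cc(CC4CCCCC4)ccc23)c1` gives 23 10^-6 cm/s. Compound 3 `COc1cccc(Oc2ccc3c(NCCCNCc4ccco4)ccnc3c2)c1` gives 317 10^-6 cm/s, which is the highest of the three numbers. The step of a 14-fold higher number from compound 1 to compound 3 (1.14 log units; beyond the scatter) and the step of a 14-fold higher number from compound 2 to compound 3 (1.14 log units; beyond the scatter) each replace the entire group attached to the core, while the step of no change at the digits printed from compound 1 to compound 2 (within the scatter) also swaps one whole group for another.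

Compound 4 `CN(C)c1cccc(Oc2ccc3c(NCCCNCc4ccco4)ccnc3c2)c1` differs from compound 3 in a much smaller way: dimethylamino in place of methoxy on an aromatic carbon. For the measured compounds named here, none of the measured steps changes only a small group on the 3-methoxyphenoxy ring; each of them exchanges the whole group on the core, so no measured comparison shows what this particular exchange does in this assay. Going by the values given here, with no step bearing on it directly, the expected step is a 1.1-fold lower number from compound 3 to compound 4 (0.02 log units; within the scatter), within the scatter. Compound 4 is therefore estimated at 300 10^-6 cm/s, with a range from 120 10^-6 cm/s to 600 10^-6 cm/s.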

Compound 4, apparent permeability: 317 10^-6 cm/s
Beside the measured number, compound 4's estimate is 1.1-fold (0.02 log units) below it, and the stated range covers the measured number.
By their numbers in this assay, from the lowest: compounds 1 and 2 (each within the scatter of the next); then compounds 3 and 4 (each within the scatter of the next).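

In this assay, for the compounds shown here, the only step confined to a small group on the phenoxy ring, dimethylamino in place of methoxy, gives no change at the digits printed from compound 3 to compound 4 (within the scatter), so these two groups cannot be told apart at this place on the ring by this read-out. The large steps seen with compound 3 persist with the new group, as a 14-fold higher number from compound 2 to compound 4 (1.14 log units; beyond the scatter) and a 14-fold higher number from compound 1 to compound 4 (1.14 log units; beyond the scatter) show, so replacing methoxy with dimethylamino leaves the gap to compounds 1 and 2 intact. No measurement offers a reason for these numbers.

The compounds shown leave open whether this flat result extends to a very different group on the same carbon, such as a carboxylic acid or a primary amine. They also leave open what a longer chain, such as propoxy, would do there.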